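This account rests on a few compounds, and the source may have more. Where it says the series, first, only, none or still open, it means among the compounds named here.

Three compounds share one core and differ only in the aryl group on a saturated ring carbon. Compound 1 `COc1cc(/C=C/C(=O)C2=C(/C=C/c3ccc(O)c(OC)c3)NC(=O)NC2c2ccccc2)ccc1O` gives 40.2% in a functional assay, with a stated time of 20 min, tested at 50 uM; a higher number here means a stronger effect of the compound at the concentration tested, a lower number a weaker effect. Compound 2 `COc1cc(/C=C/C(=O)C2=C(/C=C/c3ccc(O)c(OC)c3)NC(=O)NC2c2ccccc2O)ccc1O` gives 88.9% in this assay, and compound 3 `COc1cc(/C=C/C(=O)C2=C(/C=C/c3ccc(O)c(OC)c3)NC(=O)NC2c2cccc([N+](=O)[O-])c2)ccc1O` gives 71% in this assay. Compound 3 thus stands second of the three: a number 17.9 percentage points lower from compound 2 to compound 3 (beyond the scatter), while a number 30.8 percentage points higher from compound 1 to compound 3 (beyond the scatter). Compound 4 `COc1cc(/C=C/C(=O)C2=C(/C=C/c3ccc(O)c(OC)c3)NC(=O)NC2c2ccccc2Cl)ccc1O` carries the change (2-chlorophenyl in place of 3-nitrophenyl on a saturated ring carbon). Within the data shown here, two measured steps bear on it, both pointing upward from the plain phenyl: a number 48.7 percentage points higher from compound 1 to compound 2 (beyond the scatter) and a number 30.8 percentage points higher from compound 1 to compound 3 (beyond the scatter). Among the measured compounds shown here, no measured compound carries chlorine, so how a 2-chlorophenyl group behaves here is unknown. The hydroxy step was larger than the nitro step, and a number 17.9 percentage points lower from compound 2 to compound 3 (beyond the scatter) places the 2-hydroxyphenyl compound ahead. Compound 4 is expected to stay above compound 1 without reaching compound 2. For compound 4 the expected step is a number 1 percentage points lower from compound 3 to compound 4 (within the scatter), within the scatter. Compound 4 is therefore estimated at 70% in this assay, with a range from 45% to 90%.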

Compound 4, a percentage reported as activity, at one concentration (the size of the read-out at that concentration, not a potency): 55.5%
Compound 4: middle estimate off by 14.5 percentage points, on the high side, within the range that was stated.
By their numbers in this assay, from the lowest: compound 1; then compound 4; then compound 3; then compound 2.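

Chlorine also lifts the read-out in this assay above the plain phenyl, with a number 15.3 percentage points higher from compound 1 to compound 4 (beyond the scatter), so all three substituted aryl groups shown stand above compound 1, and the size of the gain depends on the group: at the same ring place, a number 33.4 percentage points lower from compound 2 to compound 4 (beyond the scatter) when chloro replaces hydroxy. The 2-chlorophenyl group also falls short of the 3-nitrophenyl group, with a number 15.5 percentage points lower from compound 3 to compound 4 (beyond the scatter), but these two differ in both the group and its place on the aryl ring, so this step cannot separate the two changes. Nothing available here explains why these groups differ.

Still open, on these data alone, is whether 2-nitrophenyl would match 3-nitrophenyl, and whether 3-chlorophenyl would match 2-chlorophenyl. Also open, as far as these compounds go, is how an amine, a carboxylic acid or a methoxy group would fare on this aryl ring.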